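Swapping the piperidine cap: carbamate to oxadiazolylmethyl

This account rests on a few compounds, and the source may have more. Where it says the series, first, only, none or still open, it means among the compounds named here.

Of the compounds shown here, three sharing one core have been measured in a functional assay on isolated protein for agonist activity at Glucose-dependent insulinotropic receptor (Homo sapiens), read by HTRF and cAMP accumulation; a higher number here means a larger maximal response, a lower number a smaller maximal response. Compound 1 `CC(C)OC(=O)N1CCC(O[C@H]2CC[C@H](Oc3ccc(S(C)(=O)=O)nc3)CC2)CC1` gives 101%. Compound 2 `Cc1nc(O[C@H]2CC[C@H](OC3CCN(C(=O)OC(C)(C)C)CC3)CC2)ccc1C(=O)N(C)C` gives 121%. Compound 3 `CC1(OC(=O)N2CCC(O[C@H]3CC[C@H](Oc4cnc(S(C)(=O)=O)cn4)CC3)CC2)CC1` gives 118%, which is the second highest of the three numbers; compound 2 lies within the usual scatter of it, while compound 1 lies beyond the scatter, lower than compound 3.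

Compound 4 `CC(F)Cc1nc(CN2CCC(O[C@H]3CC[C@H](Oc4cnc(S(C)(=O)=O)cn4)CC3)CC2)no1` has not yet been measured. It differs from compound 3 in one place: (5-(2-fluoropropyl)-1,2,4-oxadiazol-3-yl)methyl in place of ((1-methylcyclopropyl)oxy)carbonyl on an amine nitrogen in a ring. The group on the amine nitrogen in a ring is thus exchanged for a larger one holding a five-membered aromatic ring with 3 hetero atoms, while the rest of the molecule is kept.

Going by the values given here, no step between two measured compounds of this kind is available, so the expectation rests on the three numbers alone, all of which describe a full response. Compound 4 is therefore expected to give a largest response near that of compound 3, and the step of a number 8 percentage points lower from compound 3 to compound 4 (within the scatter) is estimated to stay within the scatter. The estimate for compound 4 is 110%, with a range from 90% to 125%.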

Compound 4, largest response reached (Emax), in percent of the reference or control that the assay uses: 97%
Estimate against measurement, compound 4: 13 percentage points above; measured number inside the range.
By their numbers in this assay, from the lowest: compounds 4 and 1 (each within the scatter of the next); then compounds 3 and 2 (each within the scatter of the next).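

Replacing the group on the amine nitrogen in a ring has a real effect in this assay: the exchange of ((1-methylcyclopropyl)oxy)carbonyl for (5-(2-fluoropropyl)-1,2,4-oxadiazol-3-yl)methyl gives a number 21 percentage points lower from compound 3 to compound 4 (beyond the scatter), the first single-place step available in this series. The carbamate is therefore not required for a response, since compound 4 still reaches 97% with a five-membered aromatic ring in that place, but this position does affect the size of the maximal response. No measurement shown here explains the lower number.

All parts of the new group enter together, so the five-membered aromatic ring, its methyl link and the 2-fluoropropyl chain cannot be judged separately. From the compounds shown here alone, how a propyl chain without the fluorine, or a benzyl group on the same nitrogen, would compare remains open.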